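The source may hold more compounds than are shown below. What is called first, only, known or untested is meant among the compounds shown, and "the series" means these compounds.

Measured in a functional assay on HT-29 cells (Homo sapiens) for antiproliferative activity, read by XTT assay, with a stated time of 72 h; on this read-out higher numbers stand for weaker inhibition and lower numbers for stronger inhibition:
- Compound 1 `C=C(C)CCC[C@]1(C)C2=CCC[C@](C)(CC(=O)c3ccoc3)[C@H]2CC[C@H]1C`: > 100000 nM (a limit of the assay, not a number)
- Compound 2 `C=C(C)CCC[C@]1(C)C2=CCC[C@](C)(C[C@H](O)C3=CC(=O)OC3O)[C@H]2CC[C@H]1C`: 3000 nM

Compound 1 sits at the limit of > 100000 nM in this assay, at which 1 of the 2 values shown sits. Among the compounds with values here, that leaves compound 2, at 3000 nM, with the only true number so far, and so it is the sole anchor for any estimate.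

Compound 3 `C=C(C)CCC[C@]1(C)C2=CCC[C@](C)(C[C@H](O)c3ccoc3)[C@H]2CC[C@H]1C` has not yet been measured. The change is a group of 5 heavy atoms (4 carbon, 1 oxygen; one five-membered aromatic ring with 1 hetero atom) in place of a group of 7 heavy atoms (4 carbon, 3 oxygen; one five-membered non-aromatic ring with 1 hetero atom), on a saturated chain carbon bound to an oxygen on a saturated carbon and a saturated chain carbon. In plain terms, the five-membered non-aromatic ring leaves and furan-3-yl enters, on a saturated chain carbon bound to an oxygen on a saturated carbon and a saturated chain carbon.

Within the data shown here, one measured step bears on this: an at least 33-fold lower number from compound 1 to compound 2 (1.52 log units; beyond the scatter). In that step a furan ring left and a five-membered non-aromatic ring entered, the reverse of the present exchange, although the group exchanged there was larger. Only part of that large gain is therefore expected to be lost, but the loss should still lie beyond the scatter, toward weaker inhibition in this assay. The expected step is a 10-fold higher number from compound 2 to compound 3 (1.00 log units; beyond the scatter). For compound 3 the estimated value is 30000 nM, with an expected range from 8000 nM to 100000 nM.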

Compound 3, half-maximal inhibitory concentration: 63100 nM
For compound 3 the middle estimate is 2.1-fold (0.32 log units) below the measured one; low and high end bracket the measured number.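

In this assay, exchanging the five-membered non-aromatic ring for furan-3-yl while the oxygen on the chain stays in place gives a 21-fold higher number from compound 2 to compound 3 (1.32 log units; beyond the scatter), so this ring exchange alone, on a saturated chain carbon bound to an oxygen on a saturated carbon and a saturated chain carbon, is enough to cost a large part of the activity. With furan-3-yl held fixed, (furan-3-yl)(hydroxy)methyl in place of (furan-3-yl)carbonyl gives an at least 1.5-fold lower number from compound 1 to compound 3 (0.19 log units; that floor lies within the scatter), and as that floor lies within the scatter, this change can neither be credited with a gain nor be ruled out as a source of one. The value of compound 1 is a limit and not a number, which leaves this second comparison open at its upper side: the limit of > 100000 nM in this assay, at which 1 of the 3 values shown sits.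

The compounds shown do not tell which part of the non-aromatic ring matters, as its ring hydroxyl, its carbonyl and its double bond all leave together with it. A carboxylic acid or an amine at the same place on the chain could show whether any of the ring's atoms can be replaced while the activity of compound 2 is kept.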